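Tetrazolylmethyl Thioether Variant of a Diaminodicyanopyridine Series

A few compounds are considered here, and "the series" means these few. Any claim that something is new, unique, unknown or untested is made for them only; others in the source may bear on it.

Compound 1, `N#Cc1c(N)nc(SCC(N)=O)c(C#N)c1-c1ccc(OCC2CC2)cc1`: 8%
Compound 2, `N#Cc1c(N)nc(SCc2cccc(C(N)=O)c2)c(C#N)c1-c1ccc(OCC2CC2)cc1`: 1%

In an assay on CHO cells for displacement of a labelled ligand from adenosine receptor A3 (Homo sapiens), read by scintillation counting, with a stated time of 120 min, tested at 1 uM (a lower number here means less inhibition, a higher number more inhibition at the concentration tested (going by the name of the read-out)), compound 2 gives 1%, and compound 1 gives 8%; the two lie within the usual scatter of each other, as a number 7 percentage points lower from compound 1 to compound 2 (within the scatter) shows. Compound 3, `N#Cc1c(N)nc(SCc2nnn[nH]2)c(C#N)c1-c1ccc(OCC2CC2)cc1`, differs from compound 2 in one place: 1H-tetrazol-5-yl in place of 3-carbamoylphenyl on a saturated chain carbon bound to a sulfur. Within the data shown here, no measured step bears on this change, so the estimate rests on the values of compound 1 and compound 2 and on the step between them, which stayed within the scatter. Compound 3 is therefore expected to show a number 4 percentage points higher from compound 2 to compound 3 (within the scatter), no step beyond the scatter. Compound 3 is estimated at 5%, between -5% and 18%.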

Compound 3, a percentage reported as inhibition, at one concentration (the size of the read-out at that concentration, not a potency): 1%
Beside the measured number, compound 3's estimate is 4 percentage points above it; measured number inside the range.
By their numbers in this assay, from the lowest: compounds 2, 3 and 1 (each within the scatter of the next).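

In this assay the change to 1H-tetrazol-5-yl on a saturated chain carbon bound to a sulfur gives no change at the digits printed from compound 2 to compound 3 (within the scatter) and the same change from carbamoyl gives a number 7 percentage points lower from compound 1 to compound 3 (within the scatter) so all three groups now lie within the scatter of one another. At this place, then, a five-membered aromatic ring with 4 hetero atoms shows no step beyond the scatter from either 3-carbamoylphenyl or carbamoyl. No measurement at hand explains this result. As far as these compounds go, whether a carboxylic acid, an amine or a longer chain at this place would step beyond the scatter remains open.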